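The source may report more compounds than this note shows. Statements on the series, on what has been measured and on what is new or still open speak of the compounds shown alone.

Measured compounds:
compound 1, `COc1cc(-c2nn(-c3cccc(NC(=O)Nc4ccc(Cl)c(Cl)c4)c3)cc2-c2ccncc2)ccc1Cl`, 2690 nM in a functional assay on M14 cells (Homo sapiens) for inhibition, read by sulforhodamine B assay, with a stated time of 48 h; a lower number here means a stronger inhibitor of growth, a higher number a weaker inhibitor of growth
compound 2, `O=C(Nc1cccc(-n2cc(-c3ccncc3)c(-c3ccc(Cl)c(O)c3)n2)c1)Nc1ccc(Cl)c(Cl)c1`, 6970 nM in this assay

Among the compounds with values here, compound 2 has the highest of the two numbers so far; its nearest neighbour is compound 1, which differs by a 2.6-fold higher number from compound 1 to compound 2 (0.41 log units; beyond the scatter) through hydrogen in place of methyl on an oxygen on an aromatic ring. Compound 3, `O=C(Nc1cccc(-n2cc(-c3ccncc3)c(-c3ccc(Cl)c(O)c3)n2)c1)Nc1ccc(Cl)c(C(F)(F)F)c1`, has not yet been measured. It differs from compound 2 by trifluoromethyl in place of chloro on an aromatic carbon. Within the data shown here, the single known step, from compound 1 to compound 2, touches a different part of the molecule and so says nothing direct about this exchange; no measured pair here shows chloro against trifluoromethyl. With nothing pointing in either direction, the expected outcome for compound 3 in this assay is a step of a 1.1-fold lower number from compound 2 to compound 3 (0.03 log units; within the scatter), that is, no shift beyond the scatter. The estimate for compound 3 is therefore 6500 nM, within a range of 2500 nM to 17000 nM.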

Compound 3, concentration for total growth inhibition: 2770 nM
For compound 3 the middle estimate is 2.3-fold (0.37 log units) above the measured one; measured number inside the range.
By their numbers in this assay, from the lowest: compounds 1 and 3 (each within the scatter of the next); then compound 2.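

Trifluoromethyl in place of chloro on the 3,4-dichlorophenyl group gives a 2.5-fold lower number from compound 2 to compound 3 (0.40 log units; beyond the scatter) in this assay, so this position responds to the exchange and the result is a stronger inhibitor of growth. Within the data shown here, until now, the only step that could be read was the change at the oxygen on the other aromatic ring, which raised the number, so this is a second place in the molecule where one exchange moves the number beyond the scatter, and here it lowers it. Nothing measured here explains why the number falls.

As far as these compounds go, with only chloro and trifluoromethyl compared at this position, groups such as fluoro, bromo or a nitrile remain open there. From the compounds shown here alone, it also remains open whether the same exchange would lower the number in a compound carrying the methyl on the oxygen, as compound 1 does.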